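Cytotoxicity notes on a chlorobiaryl ether series

The compounds below may be only part of what the source reports. "The series", "measured", "known", "first", "only" and "open" are said of these compounds alone.

Measured compounds:
compound 1 `O=C1N(CCC(CCOc2ccc(-c3ccc(Cl)cc3)cc2)Cc2ccccc2)CCN1c1ccncc1` — > 10000 nM
compound 2 `O=C1N(Cc2ccccc2COc2ccc(-c3ccc(Cl)cc3)cc2)CCN1c1ccncc1` — > 1250 nM
compound 3 `CC(CCCCN1CCN(c2ccncc2)C1=O)Oc1ccc(-c2ccc(Cl)cc2)cc1` — > 12500 nM

The read-out in every case is an ADME assay on cells (Homo sapiens) for cytotoxicity; on this read-out lower numbers stand for higher toxicity in this test and higher numbers for lower toxicity in this test. For the measured compounds named here, no compound has yielded a number in this assay; every entry is a limit. For compound 1 the value > 10000 nM is a limit of the test, and its standing in the set is that limit itself (the limit of > 10000 nM in this assay, at which 1 of the 3 values shown sits). For compound 2 the value > 1250 nM is likewise a limit (the limit of > 1250 nM in this assay, at which 1 of the 3 values shown sits). For compound 3 the value > 12500 nM is also a limit (the limit of > 12500 nM in this assay, at which 1 of the 3 values shown sits). Going by the values given here, no two of the measured compounds differ in a single place, so no measured step in this assay exists for the series, and nothing can be said of the size of any change from the data so far.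

Compound 4 `O=C1N(CCC(CCOc2ccc(-c3ccc(Cl)cc3)cc2)C(F)(F)F)CCN1c1ccncc1` has not been measured in this assay. It is reached from compound 1 by one change: trifluoromethyl in place of benzyl on a saturated chain carbon bound to two saturated chain carbons. Among the compounds with values here, with compound 1 sitting at a limit and no measured step to draw on, the step from compound 1 to compound 4 is expected to be none beyond the scatter, that is a number no higher from compound 1 to compound 4 (the limit leaves the size open). Compound 4 is therefore expected to show in this assay a value near 10000 nM, with an estimated range from 5000 nM to 20000 nM, most likely reported as a limit once more.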

Compound 4, half-maximal cytotoxic concentration: > 12500 nM
Compound 4 was reported as a limit; the forecaster's own chance of this, stated with the estimate: 80%; at least 1.2-fold (0.09 log units) between middle value and limit.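

Compound 1 and compound 4 both stand at limits in this assay, and the step between them cannot be read. The compounds shown leave open at what concentration any of them becomes cytotoxic, and whether trifluoromethyl in place of benzyl on a saturated chain carbon bound to two saturated chain carbons changes the read-out at all.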